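A few compounds are considered here, and "the series" means these few. Any claim that something is new, unique, unknown or untested is made for them only; others in the source may bear on it.

Compound 1 `CC(C)c1ccccc1-c1cc2cc(CCC(=O)O)ccc2[nH]1`: in a functional assay on CHO cells for agonist activity at Free fatty acid receptor 1 (Homo sapiens), read by a luciferase reporter, with a stated time of 24 h (on this read-out lower numbers stand for an effect already at smaller amounts and higher numbers for an effect only at larger amounts of compound), compound 1 gives > 25 nM, which is a limit of the assay and not a number.
Compound 2 `Cn1c(-c2cccc(Cl)c2)cc2cc(CCC(=O)O)ccc21`: in this assay compound 2 gives > 10000 nM, again only a limit.
Compound 3 `COc1cccc(-c2cc3cc(CCC(=O)O)ccc3[nH]2)c1`: in this assay compound 3 gives > 25 nM, also a limit.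

Compound 1 therefore stands at a limit rather than at a measured number. Two of the three values sit at the limit of > 25 nM in this assay, at which 2 of the 3 values shown sit, and one sits at the limit of > 10000 nM in this assay, at which 1 of the 3 values shown sits. Every value is a limit. Going by the values given here, no step between the measured compounds can be read as a size, and nothing can be said about which of them is more or less potent.

The step followed here leads from compound 1 to compound 4 `CCc1ccccc1-c1cc2cc(CCC(=O)O)ccc2[nH]1`. The change is small: hydrogen in place of methyl on a saturated chain carbon bound to an aromatic carbon and a saturated chain carbon. The rest of the shared core, the acid-bearing chain and the aromatic substituent are unchanged.

Among the compounds with values here, with no measured step to lean on, the expectation is a step of no more than the usual scatter: the step from compound 1 to compound 4 is estimated as a step that the limit leaves unreadable from compound 1 to compound 4. Compound 4 is thus expected to give about 150 nM in this assay, with a range from 25 nM to 2000 nM.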

Compound 4, half-maximal effective concentration: 1800 nM
Compound 4: the middle estimate sits 12-fold (1.08 log units) below what was measured, within the range that was stated.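

In this assay compound 1 gives > 25 nM, which is a limit and not a number. Compound 4 gives 1800 nM, so the change from isopropyl to ethyl that links compound 1 and compound 4 cannot be read as a step of any size. The compounds shown leave open whether compound 1 or compound 4 acts at smaller amounts.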